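A few compounds are considered here, and "the series" means these few. Any claim that something is new, unique, unknown or untested is made for them only; others in the source may bear on it.

The measured compounds: compound 1 `CC[C@@](C)(O)CC(=O)O[C@H](CC=C(C)C)C1=CC(=O)c2c(O)ccc(O)c2C1=O` gives 17900 nM in a functional assay on HeLa cells (Homo sapiens) for cytotoxicity, read by MTT assay; a lower number here means a stronger inhibitor, a higher number a weaker inhibitor; compound 2 `CC(C)=CC[C@@H](OC(=O)C1CCOC1)C1=CC(=O)c2c(O)ccc(O)c2C1=O` gives 73500 nM; compound 3 `CCCC(C)(O)CC(=O)O[C@H](CC=C(C)C)C1=CC(=O)c2c(O)ccc(O)c2C1=O` gives 72000 nM.

Compound 2 has the highest number of the three; compound 3 sits within the scatter of it, while compound 1 lies a 4.1-fold higher number from compound 1 to compound 2 (0.61 log units; beyond the scatter) away. Compound 4 `CC(C)=CC[C@@H](OC(=O)CC(C)(O)C(C)C)C1=CC(=O)c2c(O)ccc(O)c2C1=O` differs from compound 2 by 2-hydroxy-2,3-dimethylbutyl in place of oxolan-3-yl on a carbonyl carbon. Going by the values given here, two steps bear on this change at the carbonyl carbon: a 4.1-fold higher number from compound 1 to compound 2 (0.61 log units; beyond the scatter) points to a lower number when an open hydroxyalkyl chain stands there, but a 1.0-fold lower number from compound 2 to compound 3 (0.01 log units; within the scatter) shows no shift for a longer chain of the same kind. The expected step is therefore a 1.8-fold lower number from compound 2 to compound 4 (0.26 log units; within the scatter), a lower number but of uncertain size. Compound 4 is estimated at 40000 nM, between 15000 nM and 100000 nM.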

Compound 4, half-maximal inhibitory concentration: 27700 nM
Compound 4: middle estimate off by 1.4-fold (0.16 log units), on the high side; the range from low to high includes it.
By their numbers in this assay, from the lowest: compounds 1 and 4 (each within the scatter of the next); then compounds 3 and 2 (each within the scatter of the next).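

Compound 4 shows that an open chain on the carbonyl carbon can give a lower number than oxolan-3-yl in this assay (a 2.7-fold lower number from compound 2 to compound 4 (0.42 log units; beyond the scatter)), although compound 3, also open-chained, goes against this. The outer end of the chain counts, as isopropyl in place of propyl shows (a 2.6-fold lower number from compound 3 to compound 4 (0.41 log units; beyond the scatter)), while 1-hydroxy-1,2-dimethylpropyl and 1-hydroxy-1-methylpropyl stay apart by no more than the scatter (a 1.5-fold higher number from compound 1 to compound 4 (0.19 log units; within the scatter)). Nothing measured here explains these shifts. Going by these compounds, whether an amine or a carboxylic acid on this chain would keep the numbers of compound 1 and compound 4 stays open.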